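Pentyl for methyl on a fluorinated triazole quinoline

A few compounds are considered here, and "the series" means these few. Any claim that something is new, unique, unknown or untested is made for them only; others in the source may bear on it.

Compound 1 `Cc1cc2ccccc2nc1-c1cn(CCC(F)(F)C(F)(F)C(F)(F)C(F)(F)C(F)(F)C(F)(F)C(F)(F)C(F)(F)F)nn1`: 75.8 ug/mL
Compound 2 `CCCCCCCCCCn1cc(-c2nc3ccccc3cc2CCC)nn1`: > 100 ug/mL

Of the compounds shown here, two have been tested in a functional assay on COLO 205 cells (Homo sapiens) for cytotoxicity, read by MTT assay, with a stated time of 24 h; on this read-out lower numbers stand for stronger inhibition and higher numbers for weaker inhibition. For the measured compounds named here, compound 1 gives 75.8 ug/mL and is the only one with a definite number. For compound 2 the result is a limit of the assay, > 100 ug/mL, not a number; this is the only other result, and the limit of > 100 ug/mL in this assay, at which 1 of the 2 values shown sits, is where it sits.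

Compound 3 `CCCCCc1cc2ccccc2nc1-c1cn(CCC(F)(F)C(F)(F)C(F)(F)C(F)(F)C(F)(F)C(F)(F)C(F)(F)C(F)(F)F)nn1` is not yet measured. It differs from compound 1 by butyl in place of hydrogen on a saturated chain carbon bound to an aromatic carbon, so that the methyl on the core of compound 1 becomes a pentyl. Going by the values given here, no measured pair tells how such a change moves the read-out, and compound 2 gives no number to compare. The step from compound 1 is therefore expected to be small, within the scatter, with no clear direction. Compound 3 is expected to give 80 ug/mL, between 35 ug/mL and 180 ug/mL, which means a step of a 1.1-fold higher number from compound 1 to compound 3 (0.02 log units; within the scatter).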

Compound 3, half-maximal inhibitory concentration: > 100 ug/mL
Compound 3 gave a limit, no number; the forecaster's own chance of this, stated with the estimate: 40%; middle value at least 1.2-fold (0.09 log units) from the limit.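

In this assay compound 3 gives > 100 ug/mL, which is a limit of the assay and not a number. The change from methyl to pentyl, on a saturated chain carbon bound to an aromatic carbon, therefore amounts to an at least 1.3-fold higher number from compound 1 to compound 3 (0.12 log units; that floor lies within the scatter), so this longer chain brings no measurable gain at this position, while whether it truly costs activity cannot be told. The result also adds to the values that stop at the same limit, leaving fewer definite numbers to compare: the limit of > 100 ug/mL in this assay, at which 2 of the 3 values shown sit.

As far as these compounds go, the true value of compound 3 remains open, so the full size of this step is unknown. Also open, from the compounds shown here alone, is whether a shorter chain such as ethyl, or an amine or a carboxylic acid at this position, would give a definite number lower than that of compound 1.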